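Oxazolidinone Amides: Swapping an Aryl Ether for a Butyl Ether

A few compounds are considered here, and "the series" means these few. Any claim that something is new, unique, unknown or untested is made for them only; others in the source may bear on it.

Of the compounds shown here, two have been measured in an assay on HEK293 cells for inhibition of N-acylethanolamine-hydrolyzing acid amidase (Rattus norvegicus), read by LC-MS, with a stated time of 30 min; a higher number here means a weaker inhibitor, a lower number a stronger inhibitor. Compound 1 `Cc1cccc(CCCCCC(=O)N2CCOC2=O)c1` gives 350 nM. Compound 2 `Cc1cccc(Oc2ccc(C(=O)N3CCOC3=O)cc2)c1`, which carries a diaryl ether instead of a flexible chain, gives 5210 nM in this assay; that is the higher of the two numbers, and the gap to compound 1 is well beyond the usual scatter, so compound 2 is clearly the weaker inhibitor of the pair.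

Compound 3 `CCCCOc1ccc(C(=O)N2CCOC2=O)cc1` has not yet been measured. The change is butyl in place of 3-methylphenyl on an oxygen on an aromatic ring. Going by the values given here, no single-point step between measured compounds is available, so the size of this step can only be expected, not computed. Compound 3 is expected to give 2000 nM in this assay, with a range from 500 nM to 8000 nM. The expected step of a 2.6-fold lower number from compound 2 to compound 3 (0.42 log units; beyond the scatter) would be a modest gain, because the more flexible compound 1 gave 350 nM.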

Compound 3, half-maximal inhibitory concentration: 1340 nM
Estimate against measurement, compound 3: 1.5-fold (0.17 log units) above; measured number inside the range.
By their numbers in this assay, from the lowest: compound 1; then compound 3; then compound 2.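

In this assay the swap of 3-methylphenyl for butyl on the oxygen gives a 3.9-fold lower number from compound 2 to compound 3 (0.59 log units; beyond the scatter) and so shows that an aromatic ring is not needed at this position to keep inhibition. A group with no ring and fewer heavy atoms does better here, although the gain is modest and rests on this single pair. The data at hand do not tell what lies behind this preference.

The compounds shown leave open whether a longer chain such as hexyl, a branched one such as isobutyl, or a saturated ring such as cyclohexyl on the same oxygen would lower the number further. They also leave open whether a chain carrying an amine or a carboxylic acid would be tolerated there.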